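The source may hold more compounds than are shown below. What is called first, only, known or untested is meant among the compounds shown, and "the series" means these compounds.

Measured so far in a functional assay on MDA-MB-231 cells (Homo sapiens), read by fluorescence and BrdU incorporation, with a stated time of 48 h, tested at 25 uM; a lower number here means a stronger effect, a higher number a weaker effect of the compound at the concentration tested:
compound 1 `COc1cc(OC)c(C(=O)/C=C/c2ccccc2SC)c(OC)c1` gives 16%
compound 2 `COc1cc(O)c(C(=O)/C=C/c2ccccc2OC)c(OC)c1` gives "not active" (no number reported)
compound 3 `COc1cc(OC)c(C(=O)/C=C/c2ccc(Br)cc2)c(OC)c1` gives 44%

Going by the values given here, the only step between compounds differing in one place is a number 28 percentage points higher from compound 1 to compound 3 (beyond the scatter). Compound 2 stands apart from the others: it has no number at all, only the report of no activity. Compound 4 `COc1cc(O)c(C(=O)/C=C/c2ccccc2SC)c(OC)c1` keeps the core of compound 2 and carries methylsulfanyl in place of methoxy on an aromatic carbon. Among the compounds with values here, no measured step covers this change; the step from compound 1 to compound 3 concerns the other ring and does not bear on it. Within the data shown here, the only hint is that compound 1, with the same methylsulfanyl group, gives 16%. Among the measured compounds shown here, since compound 2 has no number in this assay, no size of step can be set. Compound 4 is expected to read 60%, within 25% to 100%.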

Compound 4, a percentage reported as activity, at one concentration (the size of the read-out at that concentration, not a potency): "not active" (no number reported)
For compound 4 the study gives words and no number; no gap can be computed for the estimate.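

In this assay compound 2 gives "not active" (no number reported) and compound 4 gives "not active" (no number reported), so no step can be read between them. The compounds shown leave open whether methylsulfanyl in place of methoxy changes the read-out on this core. No measured evidence bears on this result.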